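Para-substituent swap on the phenylthiazole: chloro to cyano

The source may hold more compounds than are shown below. What is called first, only, known or untested is meant among the compounds shown, and "the series" means these compounds.

Compound 1 `O=c1[nH]c2ccc(-c3csc(-c4ccccc4)n3)cc2o1`: in an assay on isolated protein for inhibition of protein phosphatase 1D (Homo sapiens), read by malachite green (on this read-out lower numbers stand for stronger inhibition and higher numbers for weaker inhibition), compound 1 gives < 20000 nM, a limit of the assay.
Compound 2 `O=c1[nH]c2ccc(-c3csc(-c4ccc(Cl)cc4)n3)cc2o1`: in this assay compound 2 gives < 20000 nM, also a limit.

Compound 2 therefore stands only at a limit, and the limit of < 20000 nM in this assay, at which 2 of the 2 values shown sit, holds for both values shown. Going by the values given here, the one measured step, a step that the two limits leave unreadable from compound 1 to compound 2, is unreadable for the same reason. Compound 3 `N#Cc1ccc(-c2nc(-c3ccc4[nH]c(=O)oc4c3)cs2)cc1` differs from compound 2 by cyano in place of chloro on an aromatic carbon. Among the compounds with values here, no measured step bears on this change, so no direction can be read from the data. For compound 3 the expected step is a step that the limit leaves unreadable from compound 2 to compound 3, and the estimate is 10000 nM with a range from 2000 nM to 20000 nM, most likely again reported only as a limit.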

Compound 3, half-maximal inhibitory concentration: < 20000 nM
Compound 3 was reported as a limit (the forecaster's own chance of this, stated with the estimate: 70%); the middle value does not contradict the limit.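

Going by these compounds alone, no step among compound 1, compound 2 and compound 3 can be read, since all three are limits in this assay: the limit of < 20000 nM in this assay, at which 3 of the 3 values shown sit. From the compounds shown here alone, whether hydrogen, chloro and cyano differ in inhibition at this place stays open.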